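From 2-chlorobenzyl to 3-methoxybenzyl on a shared core

A few compounds are considered here, and "the series" means these few. Any claim that something is new, unique, unknown or untested is made for them only; others in the source may bear on it.

Three measured compounds share a core and differ in one group on an aromatic carbon. In a functional assay on HL-60 cells (Homo sapiens) for antiproliferative activity, with a stated time of 72 h (on this read-out higher numbers stand for weaker inhibition and lower numbers for stronger inhibition), compound 1 `OC[C@H]1O[C@@H](n2cnc3c(NCc4ccccc4F)ncnc32)[C@H](O)[C@@H]1O` gives 3200 nM, compound 2 `OC[C@H]1O[C@@H](n2cnc3c(NCc4ccccc4Cl)ncnc32)[C@H](O)[C@@H]1O` gives 1600 nM and compound 3 `COc1ccccc1CNc1ncnc2c1ncn2[C@@H]1O[C@H](CO)[C@@H](O)[C@H]1O` gives 2300 nM. Compound 2 cannot be told apart from the other two on these numbers: the data show a 2.0-fold lower number from compound 1 to compound 2 (0.30 log units; within the scatter) and a 1.4-fold higher number from compound 2 to compound 3 (0.16 log units; within the scatter).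

Compound 4 `COc1cccc(CNc2ncnc3c2ncn3[C@@H]2O[C@H](CO)[C@@H](O)[C@H]2O)c1` has not yet been measured. The change that leads to it from compound 2 is this: 3-methoxyphenyl in place of 2-chlorophenyl on a saturated chain carbon bound to a nitrogen on an aromatic ring. Put simply, 3-methoxyphenyl stands in place of 2-chlorophenyl on a saturated chain carbon bound to a nitrogen on an aromatic ring.

The closest guide is the swap of methoxy in place of chloro already seen above, and methoxy in place of fluoro gave a 1.4-fold lower number from compound 1 to compound 3 (0.14 log units; within the scatter). Among the compounds with values here, no measured compound carries a 3-methoxyphenyl group, so this guide is only partial. All three measured swaps stayed small, so no shift beyond the scatter is expected in this assay. The estimated change is a 1.5-fold higher number from compound 2 to compound 4 (0.18 log units; within the scatter). For compound 4 the expected value is 2400 nM, with an estimated range from 1000 nM to 6000 nM.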

Compound 4, half-maximal inhibitory concentration: 4900 nM
The estimate for compound 4 lay 2.0-fold (0.31 log units) below the measured number, within the range that was stated.
By their numbers in this assay, from the lowest: compounds 2, 3, 1 and 4 (each within the scatter of the next, the first and the last beyond it).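

In this assay, the swaps among 2-fluorophenyl, 2-chlorophenyl and 2-methoxyphenyl all stayed within the scatter, but 3-methoxyphenyl in place of 2-methoxyphenyl gives a 2.1-fold higher number from compound 3 to compound 4 (0.33 log units; beyond the scatter) and so leaves it, which shows that the same methoxy group can change the read-out depending on where it stands on the phenyl ring. The step from 2-chlorophenyl also leaves the scatter, with a 3.1-fold higher number from compound 2 to compound 4 (0.49 log units; beyond the scatter) as its result, so on these numbers compound 4 inhibits less strongly than compound 2 and compound 3. Compound 1 goes against any simple ranking, since a 1.5-fold higher number from compound 1 to compound 4 (0.19 log units; within the scatter) stays within the scatter and the 3-methoxyphenyl and 2-fluorophenyl groups cannot be told apart here, and nothing available offers an explanation for these shifts.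

Within the data shown here, with only one 3-methoxyphenyl compound in view, it remains open whether the weaker inhibition follows the methoxy group itself or any group placed as it is in compound 4, and a 3-chlorophenyl group on the same saturated chain carbon would help to separate the two. From the compounds shown here alone, it is also open how this position would respond to a group of a different kind, such as an amine or a carboxylic acid on the phenyl ring.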